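A few compounds are considered here, and "the series" means these few. Any claim that something is new, unique, unknown or untested is made for them only; others in the source may bear on it.

Of the compounds shown here, three from the series have been measured in an assay for binding affinity to Corticotropin releasing factor receptor (Rattus norvegicus); on this read-out lower numbers stand for stronger inhibition and higher numbers for weaker inhibition. Compound 1, `CCc1nc2c(-c3ccc(Cl)cc3Cl)ccnc2n1C(CCOC)C1CC1`, gives 1.5 nM in this assay. Compound 3, `CCc1nc2c(-c3ccc(C(F)(F)F)cc3Cl)ncnc2n1C(C1CC1)C1CC1`, gives 1.8 nM in this assay, a number that lies within the scatter of compound 1. Compound 2, `CCCC(C)n1c(CC)nc2c(-c3ccc(C(C)OC)cc3Cl)ccnc21`, gives 3.5 nM in this assay, and that gap to compound 1 lies beyond the scatter. Compound 1 therefore sits at the low end of the three numbers, with only compound 2 clearly apart from it.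

Compound 4, `CCc1nc2c(-c3ccc(Cl)cc3Cl)ccnc2n1[C@H](CC)C1CC1`, has not yet been measured. It differs from compound 1 in one place: 1-cyclopropylpropyl in place of 1-cyclopropyl-3-methoxypropyl on an aromatic nitrogen. Going by the values given here, no step between measured compounds follows this change, so its effect is not known from the data; compound 3, which carries a different group on that nitrogen and a different core, gives 1.8 nM, close to compound 1.

Compound 4 is expected to give 2 nM in this assay, within a range of 0.7 nM to 6 nM. The step of a 1.3-fold higher number from compound 1 to compound 4 (0.12 log units; within the scatter) is thus estimated to be small, with no direction beyond the scatter.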

Compound 4, inhibition constant: 0.2 nM
Compound 4: the middle estimate sits 10-fold (1.00 log units) above what was measured, outside the stated range (below it).
By their numbers in this assay, from the lowest: compound 4; then compounds 1, 3 and 2 (each within the scatter of the next, the first and the last beyond it).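

In this assay, going by these compounds alone, the group on the aromatic nitrogen turns out to be able to move the number well beyond the scatter: the earlier compounds differed in several places at once, whereas here one change gives a 7.5-fold lower number from compound 1 to compound 4 (0.88 log units; beyond the scatter). In this pair a low number does not depend on the methoxy-bearing chain, since 1-cyclopropylpropyl has no hydrogen-bond acceptor, but this group also has a defined stereocentre, and one step cannot separate these two differences. Nothing given here accounts for the size of the step.

Going by these compounds, it remains open how the opposite configuration of 1-cyclopropylpropyl would compare, and whether a hydroxyl or an amine at the end of the chain would give a similar number. On these data alone, whether the step carries over to another core, such as that of compound 3, is also open.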